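Ring-nitrogen aryl swap: nitro to methoxy

This account rests on a few compounds, and the source may have more. Where it says the series, first, only, none or still open, it means among the compounds named here.

Measured so far in a functional assay, read by spectrophotometry, with a stated time of 30 min, tested at 50 ug/mL; on this read-out higher numbers stand for a stronger effect at the one concentration tested and lower numbers for a weaker effect:
compound 1 `O=C(CN1CCN(c2ncccn2)CC1)Nc1nc2ccccc2[nH]1` gives 31%
compound 2 `COc1ccc(N2CCN(CC(=O)Nc3nc4ccccc4[nH]3)CC2)cc1` gives 25.8%
compound 3 `O=C(CN1CCN(c2ccc([N+](=O)[O-])cc2)CC1)Nc1nc2ccccc2[nH]1` gives 44.8%

Compound 3 stands highest of the three numbers, beyond the scatter from both compound 1 and compound 2. The next compound is compound 4 `COc1ccccc1N1CCN(CC(=O)Nc2nc3ccccc3[nH]2)CC1`, which differs from compound 3 in one place: 2-methoxyphenyl in place of 4-nitrophenyl on an amine nitrogen in a ring.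

The relevant measured steps all concern the same group on the ring nitrogen. The most direct is a number 19 percentage points higher from compound 2 to compound 3 (beyond the scatter), which would run in reverse here; also a number 13.8 percentage points higher from compound 1 to compound 3 (beyond the scatter) and a number 5.2 percentage points lower from compound 1 to compound 2 (within the scatter). Whether the methoxy on a different ring position behaves like the 4-methoxyphenyl of compound 2 is not known from these data, so the expectation is a modest drop in this assay, with a wide range. Compound 4 is estimated at 28% (range 15% to 42%), an expected step of a number 16.8 percentage points lower from compound 3 to compound 4 (beyond the scatter).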

Compound 4, a percentage reported as activity, at one concentration (the size of the read-out at that concentration, not a potency): 35.7%
Compound 4: the middle estimate sits 7.7 percentage points below what was measured; the range from low to high includes it.
By their numbers in this assay, from the lowest: compounds 2, 1, 4 and 3 (each within the scatter of the next, the first and the last beyond it).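

In this assay the 2-methoxyphenyl group on the ring amine nitrogen stays within the scatter of all three other groups: against 4-nitrophenyl (a number 9.1 percentage points lower from compound 3 to compound 4 (within the scatter)), against 4-methoxyphenyl (a number 9.9 percentage points higher from compound 2 to compound 4 (within the scatter)) and against pyrimidin-2-yl (a number 4.7 percentage points higher from compound 1 to compound 4 (within the scatter)). Compound 3 therefore no longer stands clear of every other compound, and the methoxy position on the phenyl ring gives no step beyond the scatter. No measurement on hand accounts for these numbers.

Still open, as far as these compounds go, is how a phenyl ring carrying an amine or a carboxylic acid would read at this nitrogen. The same holds for 2-nitrophenyl, which would pair directly with compound 3 and compound 4.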